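The source may hold more compounds than are shown below. What is called first, only, known or untested is meant among the compounds shown, and "the series" means these compounds.

In a functional assay on CHO cells for agonist activity at Melanocortin receptor 4 (Homo sapiens), read by a luciferase reporter, with a stated time of 4 h (on this read-out lower numbers stand for an effect already at smaller amounts and higher numbers for an effect only at larger amounts of compound), compound 2 `CC(C)N(C(=O)CN1C=CN(c2ccccc2)C(=O)[C@H](Cc2n[nH]c3ccccc23)C1=O)c1ccccc1` gives 1070 nM, and compound 1 `COc1ccc(N(C(=O)CN2C=CN(c3ccccc3)C(=O)C(Cc3n[nH]c4ccccc34)C2=O)C(C)C)cc1` gives 708 nM, the two within the usual scatter of each other. Compound 3 `O=C1[C@@H](Cc2n[nH]c3ccccc23)C(=O)N(c2ccccc2)C=CN1CC(=O)N1CCCCc2ccccc21` gives 100 nM, and the step of an 11-fold lower number from compound 2 to compound 3 (1.03 log units; beyond the scatter) alters the amide group, not the fused ring. Compound 4 `CC(C)N(C(=O)CN1C=CN(c2ccccc2)C(=O)[C@H](Cc2n[nH]c3cc(F)ccc23)C1=O)c1ccccc1` differs from compound 2 by fluoro in place of hydrogen on an aromatic carbon. No measured step touches that ring, so nothing among these compounds shows what such a substitution does, and the only step shown concerns another part of the molecule. A change of this kind is therefore expected to give a step of a 1.1-fold lower number from compound 2 to compound 4 (0.03 log units; within the scatter), not beyond the scatter. For compound 4 the expected value in this assay is 1000 nM, with a range from 400 nM to 2500 nM.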

Compound 4, half-maximal effective concentration: 1260 nM
Estimate against measurement, compound 4: 1.3-fold (0.10 log units) below; low and high end bracket the measured number.
By their numbers in this assay, from the lowest: compound 3; then compounds 1, 2 and 4 (each within the scatter of the next).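

Fluoro in place of hydrogen on this aromatic carbon is the first measured change on this ring, and in this assay it gives a 1.2-fold higher number from compound 2 to compound 4 (0.07 log units; within the scatter) and so leaves the number unchanged within the scatter. The amide change, by contrast, gives an 11-fold lower number from compound 2 to compound 3 (1.03 log units; beyond the scatter) and moves the number beyond the scatter. Nothing available explains the fluoro result.

As far as these compounds go, whether an amine or a carboxylic acid on this same carbon would move the number remains open. So does whether fluoro on the other carbons of this ring would behave the same way.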